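The source may report more compounds than this note shows. Statements on the series, on what has been measured and on what is new or still open speak of the compounds shown alone.

Compound 1, `COc1ccc(Cn2c(SCc3cc([N+](=O)[O-])cc([N+](=O)[O-])c3)nnc2-c2ccccc2)cc1`, gives in an ADME assay on A-431 cells (Homo sapiens) for cytotoxicity, with a stated time of 48 h (a lower number here means a stronger inhibitor, a higher number a weaker inhibitor), only a limit, > 30000 nM.
Compound 2, `O=[N+]([O-])c1cc(CSc2nnc(-c3ccccc3)n2Cc2ccccc2)cc([N+](=O)[O-])c1`, gives in this assay only a limit, > 30000 nM.
Compound 3, `Cn1c(SCc2ccccc2)nnc1-c1cc([N+](=O)[O-])cc([N+](=O)[O-])c1`, gives in this assay only a limit, > 30000 nM.

All three measured compounds share one kind of core, and none of them reaches a readable number in this assay: the three values sit at the same limit, (the limit of > 30000 nM in this assay, at which 3 of the 3 values shown sit). Between compound 2 and compound 1 the only change is methoxy in place of hydrogen on an aromatic carbon, and the step that the two limits leave unreadable from compound 2 to compound 1 is therefore unreadable. Compound 3 and compound 2 differ in more than one place, and the difference between the two cores is not broken down here.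

Compound 4, `COc1ccc(CSc2nnc(-c3cc([N+](=O)[O-])cc([N+](=O)[O-])c3)n2C)cc1`, is the compound not yet measured. It stands to compound 3 as compound 1 stands to compound 2: the change is methoxy in place of hydrogen on an aromatic carbon, and since the two place descriptions read the same, this is the same change as before. Among the compounds with values here, the one earlier example of the change gave no readable step, and compound 3 itself offers only a limit, so there is no measured size on which to build. The expectation for compound 4 in this assay is therefore simply that it stays where its neighbours sit, with an estimated step that the limit leaves unreadable from compound 3 to compound 4 from compound 3. Compound 4 is estimated at 45000 nM in this assay, with an expected range from 20000 nM to 120000 nM, and most likely the assay will again report only a limit.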

Compound 4, half-maximal inhibitory concentration: > 30000 nM
Compound 4 ended at the assay's limit; the forecaster's own chance of this, stated with the estimate: 85%; the middle value lies beyond the limit too.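

Compound 3 and compound 4 each give only a limit in this assay, not a number, so the size of the step between them, methoxy in place of hydrogen, cannot be read. The compounds shown leave open whether any compound with this kind of core reaches a readable number, and what the methoxy change does to such a number, as all of them stand at one value: the limit of > 30000 nM in this assay, at which 4 of the 4 values shown sit.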